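This account rests on a few compounds, and the source may have more. Where it says the series, first, only, none or still open, it means among the compounds named here.

Compound 2 `N#Cc1cc(F)cc(C(=O)Nc2cccc(Cl)c2)c1` gives 45 nM in an in vitro functional assay on HEK293-A cells for antagonist activity at metabotropic glutamate receptor 5 (Rattus norvegicus), read by calcium flux (a lower number here means a stronger inhibitor, a higher number a weaker inhibitor), the lowest of the two numbers shown; compound 1 `N#Cc1cc(F)cc(C(=O)Nc2cccc(F)c2)c1` gives 2160 nM in this assay. Among the compounds with values here, the only measured step, a 48-fold lower number from compound 1 to compound 2 (1.68 log units; beyond the scatter), concerns a chloro in place of a fluoro and does not bear on the change to compound 3 `N#Cc1cc(F)cc(C(=O)Nc2cc(F)cc(Cl)c2)c1`: fluoro in place of hydrogen on an aromatic carbon, on a six-membered aromatic ring of carbon only, meta to a chloro group and meta to a large group. Within the data shown here, no measured step speaks to adding a fluoro, so a step within the scatter in this assay is expected, a 1.1-fold lower number from compound 2 to compound 3 (0.05 log units; within the scatter). Compound 3 is estimated at 40 nM, with a range from 12 nM to 140 nM.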

Compound 3, half-maximal inhibitory concentration: 1830 nM
The estimate for compound 3 lay 46-fold (1.66 log units) below the measured number, and the stated range ends below it.
By their numbers in this assay, from the lowest: compound 2; then compounds 3 and 1 (each within the scatter of the next).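

Fluoro in place of hydrogen at this position, meta to a chloro group and meta to a large group, is not a neutral change in this assay (a 41-fold higher number from compound 2 to compound 3 (1.61 log units; beyond the scatter)). The gain seen with chloro on the fluoro-free ring does not appear once a fluoro is present: chloro in place of hydrogen on compound 1 gives (a 1.2-fold lower number from compound 1 to compound 3 (0.07 log units; within the scatter)). Nothing shown accounts for this loss. Going by these compounds, it remains open whether a methyl or methoxy group at this position would be tolerated alongside the chloro group. On these data alone, whether a larger halogen such as bromo would behave as fluoro does also remains open.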